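This account rests on a few compounds, and the source may have more. Where it says the series, first, only, none or still open, it means among the compounds named here.

Compound 1, `COC(=O)c1cc(-c2cccc(NC(=O)c3ccc(/C=C/C(=O)c4ccccc4OC)cc3)c2)on1`, in an ADME assay on Vero cells (Chlorocebus sabaeus) for cytotoxicity, read by MTT assay, with a stated time of 72 h (a higher number here means that more compound is tolerated, a lower number that less compound is tolerated), gives > 40 ug/mL, which is a limit of the assay rather than a measured number.
Compound 2, `COC(=O)c1cc(-c2cccc(NC(=O)c3ccc(/C=C/C(=O)c4ccc(C)cc4)cc3)c2)on1`, in this assay gives > 80 ug/mL, again a limit and not a number.

Among the compounds with values here, compound 2 therefore stands at a limit in this assay, and the only other value shown is a limit as well, so no measured number places it. Compound 3 is `COC(=O)c1cc(-c2cccc(NC(=O)c3ccc(/C=C/C(=O)c4ccccc4Br)cc3)c2)on1`, not yet measured. It differs from compound 2 in one place: 2-bromophenyl in place of 4-methylphenyl on a carbonyl carbon. Within the data shown here, the one measured step that touches this carbonyl carbon, a step that the two limits leave unreadable from compound 1 to compound 2, cannot be read because the limit of > 40 ug/mL in this assay, at which 1 of the 2 values shown sits, and the limit of > 80 ug/mL in this assay, at which 1 of the 2 values shown sits, are both limits, so its size is unknown. Nothing measured here sets the size or direction of the change to compound 3, and both compounds shown were tolerated up to their limits. Compound 3 is therefore expected to be tolerated in much the same way, with an estimate of 80 ug/mL and a range from 30 ug/mL to 200 ug/mL, most likely reported again only as a limit. The step this estimate means, a number no higher from compound 2 to compound 3 (the limit leaves the size open), is expected to lie within the scatter.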

Compound 3, half-maximal cytotoxic concentration: > 40 ug/mL
Compound 3 gave a limit, no number; the forecaster's own chance of this, stated with the estimate: 70%; the middle value lies beyond the limit too.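

The steps linking compound 1, compound 2 and compound 3 cannot be read, since every value in this assay is a limit and not a number: the limit of > 40 ug/mL in this assay, at which 2 of the 3 values shown sit, and (the limit of > 80 ug/mL in this assay, at which 1 of the 3 values shown sits). The compounds shown leave open at what concentration any of them harms the cells, and whether the group on the carbonyl carbon changes that.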